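An aminomethyl to fluoromethyl swap in an antiproliferative assay

The source may report more compounds than this note shows. Statements on the series, on what has been measured and on what is new or still open speak of the compounds shown alone.

Compound 1 `Cc1cn([C@@H]2O[C@H](CO)[C@@H](CF)[C@H]2O)c(=O)[nH]c1=O`: > 100 uM
Compound 2 `Cc1cn([C@@H]2O[C@H](CO)[C@@H](CN)[C@@H]2O)c(=O)[nH]c1=O`: > 100 uM

Both compounds were tested in a functional assay on P388 cells (Mus musculus) for antiproliferative activity, with a stated time of 72 h (a lower number here means that less compound is needed, a higher number that more compound is needed for the effect), and neither gave a number. Compound 2 sits at the limit of > 100 uM in this assay, at which 2 of the 2 values shown sit. Compound 3 `Cc1cn([C@@H]2O[C@H](CO)[C@@H](CF)[C@@H]2O)c(=O)[nH]c1=O` differs from compound 2 by fluoro in place of amino on a saturated chain carbon bound to a saturated ring carbon, which is fluoro in place of amino on a saturated chain carbon bound to a saturated ring carbon. No change beyond the scatter is expected in this assay for this swap, with the estimated step being a step that the limit leaves unreadable from compound 2 to compound 3. This expectation rests on compound 1, also a fluoromethyl compound, whose limit is > 100 uM. Compound 3 is expected at 150 uM, within an estimated range of 50 uM to 400 uM.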

Compound 3, concentration for half-maximal effect: > 100 uM
Compound 3 gave a limit, no number (the forecaster's own chance of this, stated with the estimate: 85%); the middle value is on the limit's open side.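

For the compounds shown here, compound 1, compound 2 and compound 3 each gave only a limit in this assay, and no step between them can be read. The compounds shown leave open whether fluoro in place of amino, or the difference in configuration as drawn, has any effect in this assay.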